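From a sulfonyl chloride to a dimethylsulfamoyl compound

A few compounds are considered here, and "the series" means these few. Any claim that something is new, unique, unknown or untested is made for them only; others in the source may bear on it.

In a functional assay on the whole organism (strain Sprague-Dawley) for inhibition, with Rattus norvegicus as the target, with a stated time of 10 min (on this read-out lower numbers stand for an effect already at smaller amounts and higher numbers for an effect only at larger amounts of compound), compound 1 (`CCOc1ccc([N+](=O)[O-])cc1-c1ncc(C(=O)O)c(=O)[nH]1`) gives 25 mg/kg as its measured dose. For compound 2 (`CCOc1ccc(S(=O)(=O)Cl)cc1-c1ncc(C(=O)O)c(=O)[nH]1`) the entry reads "not determined" (no result reported) and so it stands nowhere on this scale. Compound 3 (`CCOc1ccc(S(=O)(=O)N(C)C)cc1-c1ncc(C(=O)O)c(=O)[nH]1`) is the next structure to be tested. The change dimethylamino in place of chloro on a sulfonyl sulfur puts dimethylamino in place of chloro on a sulfonyl sulfur. Compound 2 gives no number to step from. Only compound 1 at 25 mg/kg offers one, so in this assay no step beyond the usual scatter is expected, in either direction. Compound 3 is expected at 20 mg/kg and estimated to fall from 5 mg/kg to 70 mg/kg when measured.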

Compound 3, dose for 50% inhibition: > 50 mg/kg
Compound 3 gave a limit, no number; the forecaster's own chance of this, stated with the estimate: 10%; middle value at least 2.5-fold (0.39 log units) from the limit.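

For compound 3, this assay gives a limit and not a number: the limit of > 50 mg/kg in this assay, at which 1 of the 3 values shown sits.

Putting dimethylsulfamoyl in place of nitro on an aromatic carbon gives an at least 2.0-fold higher number from compound 1 to compound 3 (0.30 log units; that floor lies within the scatter), so this position now has its first reading with a sulfonyl group. Since that floor lies within the scatter, it does not establish a real difference between the two compounds, and compound 2 offers no number for judging the change from chloro to dimethylamino.

On these data alone, the true dose of compound 3 remains open. So does how a plain amino group or a longer chain such as diethylamino on the sulfonyl sulfur would read.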